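Working notes: bromo for methyl at the sulfonyl ring

The source may report more compounds than this note shows. Statements on the series, on what has been measured and on what is new or still open speak of the compounds shown alone.

Measured compounds:
- compound 1 `Cc1ccc(S(=O)(=O)c2nc3ccccc3nc2Nc2cccc(N)c2)cc1`: 1080 nM in a functional assay on HL-60 cells (Homo sapiens) for cytotoxicity, read by MTT assay, with a stated time of 72 h; on this read-out higher numbers stand for weaker inhibition and lower numbers for stronger inhibition
- compound 2 `Cc1ccc(S(=O)(=O)c2nc3ccccc3nc2Nc2ccc(F)cc2)cc1`: 5100 nM in this assay
- compound 3 `Cc1ccc(S(=O)(=O)c2nc3ccccc3nc2Nc2ccc(C(F)(F)F)cc2)cc1`: 270 nM in this assay

Compound 3 has the lowest number of the three in this assay. It is separated from the others by a 4.0-fold lower number from compound 1 to compound 3 (0.60 log units; beyond the scatter) and by a 19-fold lower number from compound 2 to compound 3 (1.28 log units; beyond the scatter); the remaining measured step is a 4.7-fold higher number from compound 1 to compound 2 (0.67 log units; beyond the scatter). All three measured steps alter the group on a nitrogen on an aromatic ring, and none touches the (4-methylphenyl)sulfonyl part of the shared core.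

Compound 4 `O=S(=O)(c1ccc(Br)cc1)c1nc2ccccc2nc1Nc1ccc(C(F)(F)F)cc1` differs from compound 3 only there: bromo in place of methyl on an aromatic carbon, on an aromatic carbon of a six-membered aromatic ring of carbon only, para to a large group; read one bond further out, (4-methylphenyl)sulfonyl becomes (4-bromophenyl)sulfonyl. Among the measured compounds shown here, no measured step bears on this position, so no direction can be taken from the data. The expectation is therefore a step no larger than the scatter, a 1.1-fold higher number from compound 3 to compound 4 (0.05 log units; within the scatter). For compound 4 the estimate in this assay is 300 nM, with a range of 100 nM to 900 nM.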

Compound 4, half-maximal inhibitory concentration: 280 nM
Compound 4: middle estimate off by 1.1-fold (0.03 log units), on the high side; low and high end bracket the measured number.
By their numbers in this assay, from the lowest: compounds 3 and 4 (each within the scatter of the next); then compound 1; then compound 2.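

In this assay, among the compounds shown here, the only measured change at the (4-methylphenyl)sulfonyl part gives a 1.0-fold higher number from compound 3 to compound 4 (0.02 log units; within the scatter) and so shows no separation between methyl and bromo at this position while 4-(trifluoromethyl)phenyl stays on the nitrogen. The earlier compounds shown here varied only the group on the nitrogen, with a step as large as a 19-fold lower number from compound 2 to compound 3 (1.28 log units; beyond the scatter) in that place, and gave no reading at this position. No measured evidence bears on this result.

As far as these compounds go, it remains open whether bromo in place of methyl reads the same with 3-aminophenyl or 4-fluorophenyl on the nitrogen, the groups carried by compound 1 and compound 2. Also open, from the compounds shown here alone, is how this assay responds when an amine, a carboxylic acid or a longer chain takes the place of the methyl on the sulfonyl ring.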